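The compounds below may be only part of what the source reports. "The series", "measured", "known", "first", "only" and "open" are said of these compounds alone.

In a physicochemical assay for lipophilicity (a lower number here means a more polar compound, a higher number a more lipophilic compound), compound 1 `COc1ccccc1C1=NC(c2ccccc2)CO1` gives 3.76 and compound 2 `Clc1ccccc1C1=NC(c2ccccc2)CO1` gives 3.56, so compound 2 stands within the scatter of compound 1. Compound 3 `Cc1ccccc1C1=NC(c2ccccc2)CO1` differs from compound 2 by one exchange, (methyl in place of chloro on an aromatic carbon), methyl in place of chloro on an aromatic carbon. Within the data shown here, only one measured step bears on this: chloro in place of methoxy on an aromatic carbon, a number 0.20 log units lower from compound 1 to compound 2 (within the scatter). With that single guide, no step beyond the scatter is expected in this assay, and the expected step is a number 0.01 log units lower from compound 2 to compound 3 (within the scatter). Compound 3 is estimated at 3.55, with an expected range of 3.25 to 3.85.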

Compound 3, partition coefficient: 3.68
Compound 3: middle estimate off by 0.13 log units, on the low side; the measured number falls inside the stated range.
By their numbers in this assay, from the lowest: compounds 2, 3 and 1 (each within the scatter of the next).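

In this assay methyl in place of chloro gives a number 0.12 log units higher from compound 2 to compound 3 (within the scatter) and methyl in place of methoxy gives a number 0.08 log units lower from compound 1 to compound 3 (within the scatter) at the same place, on an aromatic carbon ortho to a large group. Methoxy, chloro and methyl now all stand within the scatter of one another, so no exchange among these three groups has moved the number beyond it. Nothing at hand accounts for this closeness.

Still open, going by these compounds, is whether an amine, a carboxylic acid or a longer chain at this place would step beyond the scatter. On these data alone, whether the same three groups would stay this close elsewhere on the shared core is also open.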